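The source may report more compounds than this note shows. Statements on the series, on what has been measured and on what is new or still open speak of the compounds shown alone.

Compound 1 `CCCCC1([C@H](O)/C=C/[C@H]2COC(=O)N2CCSc2nc(C(=O)O)cs2)CCC1` gives 73 nM in an assay on isolated protein for agonist activity at prostaglandin E2 receptor EP4 subtype (Homo sapiens); a lower number here means that less compound is needed, a higher number that more compound is needed for the effect.
Compound 2 `CC(C)(C)CCC1([C@H](O)/C=C/[C@H]2COC(=O)N2CCSc2nc(C(=O)O)cs2)CCC1` gives 4710 nM in this assay.
Compound 3 `CCOCCC1([C@H](O)/C=C/[C@H]2COC(=O)N2CCSc2nc(C(=O)O)cs2)CCC1` gives 745 nM in this assay.

Compound 3 stands second highest of the three numbers, separated by a 10-fold higher number from compound 1 to compound 3 (1.01 log units; beyond the scatter) and by a 6.3-fold lower number from compound 2 to compound 3 (0.80 log units; beyond the scatter). The third step, a 65-fold higher number from compound 1 to compound 2 (1.81 log units; beyond the scatter), shows how strongly this position responds to a change of group. Compound 4 `COCCCC1([C@H](O)/C=C/[C@H]2COC(=O)N2CCSc2nc(C(=O)O)cs2)CCC1` differs from compound 3 by methoxymethyl in place of ethoxy on a saturated chain carbon, two bonds along the chain from a saturated ring carbon. For the measured compounds named here, no measured step repeats this change: each measured step swaps one group for another of different make-up, whereas here the same atoms are merely joined differently. The expectation is therefore a step that stays close to the scatter, a 1.1-fold lower number from compound 3 to compound 4 (0.03 log units; within the scatter), its direction uncertain. Compound 4 is estimated at 700 nM, within 150 nM to 3000 nM.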

Compound 4, half-maximal effective concentration: 705 nM
The estimate for compound 4 lay 1.0-fold (0.00 log units) below the measured number; measured number inside the range.
By their numbers in this assay, from the lowest: compound 1; then compounds 4 and 3 (each within the scatter of the next); then compound 2.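

Shifting the oxygen along the chain, 2-ethoxyethyl to 3-methoxypropyl, gives a 1.1-fold lower number from compound 3 to compound 4 (0.02 log units; within the scatter), so in this assay these two placements cannot be told apart. Compound 4 still differs from the all-carbon chain of compound 1, with methoxy in place of methyl giving a 9.7-fold higher number from compound 1 to compound 4 (0.98 log units; beyond the scatter), while it stays well clear of the tert-butyl end of compound 2, with a 6.7-fold lower number from compound 2 to compound 4 (0.82 log units; beyond the scatter). No measurement offered here accounts for these steps.

Going by these compounds, whether a terminal hydroxyl, an amine or a longer butyl chain would return the number towards that of compound 1 stays open.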